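Series notes: furan core, benzyloxy variations, liver microsome stability

This account rests on a few compounds, and the source may have more. Where it says the series, first, only, none or still open, it means among the compounds named here.

Measured so far:
- compound 1, `COc1cc(OCc2cccc(CCc3ccccc3)c2)c2cc(-c3cn4nc(OC)sc4n3)oc2c1`, in an ADME assay on microsomes from liver (Homo sapiens) for metabolic stability, with a stated time of 10 min (a lower number here means that less of the compound is left, a higher number that more of the compound is left), compound 1 gives 99%
- compound 2, `COc1cc(OCc2cccc(COc3ccccc3)c2)c2cc(-c3cn4nc(OC)sc4n3)oc2c1`, in this assay compound 2 gives 86%
- compound 3, `COc1nn2cc(-c3cc4ccc(OCc5ccccc5)cc4o3)nc2s1`, in this assay compound 3 gives 94%

Compound 2 gives the lowest of the three numbers. Among the measured compounds shown here, its nearest neighbour is compound 3, whose value sits within the scatter of compound 2; compound 1 lies further off, and the change a number 13 percentage points lower from compound 1 to compound 2 (beyond the scatter) is the only step in this set that goes beyond the scatter.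

The new compound is compound 4, `COc1cc(OCc2cccc(C#N)c2)c2cc(-c3cn4nc(OC)sc4n3)oc2c1`. It differs from compound 2 as follows: cyano in place of phenoxymethyl on an aromatic carbon. For the measured compounds named here, the one measured step, a number 13 percentage points lower from compound 1 to compound 2 (beyond the scatter), touches the same side chain region and was modest, so it is the only guide here. All three values sit high, and nothing shown points to a move outside that band; a return toward the level of compound 1 or compound 3 is as plausible as staying put. Compound 4 is therefore expected at 93%, within 82% to 100%, which amounts to an expected step of a number 7 percentage points higher from compound 2 to compound 4 (within the scatter).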

Compound 4, percent of the compound remaining: 100%
Compound 4: middle estimate off by 7 percentage points, on the low side; low and high end bracket the measured number.
By their numbers in this assay, from the lowest: compounds 2, 3, 1 and 4 (each within the scatter of the next, the first and the last beyond it).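

In this assay cyano on this aromatic carbon, meta to a large group, gives a number 14 percentage points higher from compound 2 to compound 4 (beyond the scatter) and so shows that the number stays high with the phenoxymethyl group and its aromatic ring gone. Cyano in place of phenethyl gives a number 1 percentage points higher from compound 1 to compound 4 (within the scatter) and leaves the two level; a substituent with no ring and one with a six-membered aromatic ring sit together here, so among these compounds the lower number goes with phenoxymethyl in compound 2, not with the presence of that ring. Nothing available accounts for the difference between phenoxymethyl and phenethyl.

As far as these compounds go, whether an amine, a carboxylic acid or a longer ether chain on this carbon would hold the number at the level of compound 4 stays open. With compound 4 at 100% the read-out has little room left, so further differences among the more stable analogues could go unseen.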